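The source may report more compounds than this note shows. Statements on the series, on what has been measured and on what is new or still open speak of the compounds shown alone.

Working notes on the series in a functional assay on A549 cells (Homo sapiens) for inhibition, read by MTT assay, with a stated time of 72 h; a lower number here means a stronger inhibitor, a higher number a weaker inhibitor: compound 1 (`CCc1ccc(NC(=O)C2CCN(C/C=C/c3ccccc3)CC2)cc1`) gives 19600 nM while compound 2 (`O=C(Nc1cccc(F)c1)C1CCN(C/C=C/c2ccccc2)CC1`) gives 43300 nM and compound 3 (`N#Cc1ccc(NC(=O)C2CCN(C/C=C/c3ccccc3)CC2)cc1`) gives 40200 nM on the same shared core.

Compound 3 cannot be separated from compound 2 (a 1.1-fold lower number from compound 2 to compound 3 (0.03 log units; within the scatter)) but stands on the weaker side of compound 1 (a 2.1-fold higher number from compound 1 to compound 3 (0.31 log units; beyond the scatter)).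

The next change gives compound 4 (`O=C(Nc1ccccn1)C1CCN(C/C=C/c2ccccc2)CC1`), with pyridin-2-yl in place of 4-cyanophenyl on an amide-type nitrogen.

All three measured steps change the group at this same nitrogen or on its aromatic ring. Besides the two above, the series shows a 2.2-fold higher number from compound 1 to compound 2 (0.34 log units; beyond the scatter) as its other step. These steps are therefore the closest guide, and none is larger than modest. For the measured compounds named here, no measured compound carries an aromatic ring with a hetero atom, so the effect of that feature remains untested here.

On this basis, the expected change is a 1.1-fold lower number from compound 3 to compound 4 (0.02 log units; within the scatter) and no step beyond the scatter is expected in either direction in this assay for this replacement.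

Compound 4 is estimated at 38000 nM (expected range 17000 nM to 85000 nM).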

Compound 4, half-maximal inhibitory concentration: 89300 nM
Compound 4: the middle estimate sits 2.4-fold (0.37 log units) below what was measured; measured number outside the range, above it.
By their numbers in this assay, from the lowest: compound 1; then compounds 3 and 2 (each within the scatter of the next); then compound 4.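

In this assay, for the compounds shown here, compound 4 is the weakest of the four, and it is the first compound with a hetero atom in the aromatic ring on the amide-type nitrogen: the steps to it are a 2.2-fold higher number from compound 3 to compound 4 (0.35 log units; beyond the scatter), a 2.1-fold higher number from compound 2 to compound 4 (0.31 log units; beyond the scatter) and a 4.6-fold higher number from compound 1 to compound 4 (0.66 log units; beyond the scatter). Going by these compounds alone, compound 2 and compound 3 could not be separated from each other, yet both separate from compound 4, so this position distinguishes pyridin-2-yl from the two carbon-only aromatic groups with a fluoro or cyano substituent, and the spread at this nitrogen is wider than the earlier steps showed. Nothing available explains the higher number of compound 4.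

The change to pyridin-2-yl swaps the ring and removes the ring substituent in one move, so plain phenyl on this nitrogen would be needed to separate those two parts of the step. Pyridin-3-yl and pyridin-4-yl remain open as tests of whether the place of the ring nitrogen matters, as does a pyridin-2-yl ring carrying an ethyl group, which would compare directly with compound 1.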